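A few compounds are considered here, and "the series" means these few. Any claim that something is new, unique, unknown or untested is made for them only; others in the source may bear on it.

Measured in a functional assay on HepG2 cells (Homo sapiens) for antiproliferative activity, read by MTT assay, with a stated time of 72 h; on this read-out higher numbers stand for weaker inhibition and lower numbers for stronger inhibition:
Compound 1 `NC1=NC2(CCOCC2)N(OCCCOc2ccc(Cl)cc2)C(N)=N1`: "not determined" (no result reported)
Compound 2 `NC1=NC2(CCOCC2)N(OCCCOc2cccc(Cl)c2Cl)C(N)=N1`: 330 nM
Compound 3 `Cc1cc(C)cc(OCCCON2C(N)=NC(N)=NC23CCOCC3)c1`: 680 nM

Compound 3 carries the higher of the two numbers available, with compound 2 as its nearest neighbour; compound 1 offers no number to compare. The next compound is compound 4 `NC1=NC2(CCOCC2)N(OCCCOc2ccc(Cl)c(Cl)c2)C(N)=N1`, where 3,4-dichlorophenyl takes the place of 3,5-dimethylphenyl on an oxygen on a saturated carbon: 3,4-dichlorophenyl in place of 3,5-dimethylphenyl on an oxygen on a saturated carbon. For the measured compounds named here, one measured step bears on this, a 2.1-fold higher number from compound 2 to compound 3 (0.31 log units; beyond the scatter), which replaced 2,3-dichlorophenyl with 3,5-dimethylphenyl. As compound 4 returns to a dichlorophenyl group, a similarly modest step towards a lower number is expected in this assay, though the two dichlorophenyl groups are not the same. The expected change is a 1.7-fold lower number from compound 3 to compound 4 (0.23 log units; within the scatter). For compound 4 the estimated value is 400 nM, with an expected range of 150 nM to 1000 nM.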

Compound 4, half-maximal inhibitory concentration: 380 nM
Estimate against measurement, compound 4: 1.1-fold (0.02 log units) above, within the range that was stated.
By their numbers in this assay, from the lowest: compounds 2, 4 and 3 (each within the scatter of the next, the first and the last beyond it).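

In this assay, 3,4-dichlorophenyl in place of 3,5-dimethylphenyl gives a 1.8-fold lower number from compound 3 to compound 4 (0.25 log units; within the scatter) and so cannot be told from that group at this position on its own. The exchange of one dichlorophenyl group for the other gives a 1.2-fold higher number from compound 2 to compound 4 (0.06 log units; within the scatter) and shows that these two chlorine patterns read alike here. Nothing at hand explains these numbers.

Still open, as far as these compounds go, is how a phenyl ring carrying an amine or a carboxylic acid would read in this assay at this position. Whether a longer chain to the ring would keep these numbers is open too.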